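The compounds below may be only part of what the source reports. "The series", "measured", "known", "first", "only" and "open" are said of these compounds alone.

Measured compounds:
compound 1 `O/N=C(\CCN1CCN(c2ccccn2)CC1)c1ccccc1Cl`, 24 nM
compound 2 `O/N=C(\CCN1CCN(c2ccccn2)CC1)c1cccc(Cl)c1`, 11.9 nM

In a functional assay on HEK293 cells with D(4) dopamine receptor (Homo sapiens) as the target, read by FLIPR (on this read-out lower numbers stand for an effect already at smaller amounts and higher numbers for an effect only at larger amounts of compound), compound 2 has the smaller of the two numbers, but a 2.0-fold lower number from compound 1 to compound 2 (0.30 log units; within the scatter) lies within the scatter, so the two compounds are not separated. Compound 3 `Cc1cc(C)cc(/C(CCN2CCN(c3ccccn3)CC2)=N/O)c1` carries 3,5-dimethylphenyl in place of 3-chlorophenyl on a carbon with a double bond to nitrogen. Going by the values given here, no measured step covers this exchange; the only step available, compound 1 to compound 2, is within the scatter and concerns a different change. Compound 3 is therefore expected to show no step beyond the scatter, a 1.7-fold higher number from compound 2 to compound 3 (0.23 log units; within the scatter), with wide uncertainty. For compound 3 the estimate is 20 nM, range 6 nM to 70 nM.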

Compound 3, half-maximal effective concentration: 45.8 nM
Estimate against measurement, compound 3: 2.3-fold (0.36 log units) below; measured number inside the range.
By their numbers in this assay, from the lowest: compounds 2, 1 and 3 (each within the scatter of the next, the first and the last beyond it).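

In this assay, going by these compounds alone, 3,5-dimethylphenyl in place of 3-chlorophenyl gives a 3.8-fold higher number from compound 2 to compound 3 (0.59 log units; beyond the scatter) and is the first exchange to move the number beyond the scatter, so this position is not indifferent to its aryl group. Measured against the 2-chlorophenyl compound, the same group gives a 1.9-fold higher number from compound 1 to compound 3 (0.28 log units; within the scatter) and separates nothing. No available evidence bears on the origin of this step.

Still open, going by these compounds, is whether the step follows from losing the chlorine or from carrying two methyl groups. Unsubstituted phenyl and 3-methylphenyl on the shared core would help to separate these.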